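Bromophenyl Urea Replaces Propyl Amide at the Piperidine Carbonyl

A few compounds are considered here, and "the series" means these few. Any claim that something is new, unique, unknown or untested is made for them only; others in the source may bear on it.

Measured compounds:
- compound 1 `CCC(=O)N1CCC(CN(C2Cc3cc(C#N)ccc3N(Cc3cncn3C)C2)S(=O)(=O)c2ccccn2)CC1`: 0.5 10^-6 cm/s
- compound 2 `CCCC(=O)N1CCC(CN(C2Cc3cc(C#N)ccc3N(Cc3cncn3C)C2)S(=O)(=O)c2ccccn2)CC1`: 0.5 10^-6 cm/s
- compound 3 `Cn1cnc(S(=O)(=O)N(Cc2cccc(-n3cccc3)c2)C2Cc3cc(C#N)ccc3N(Cc3cncn3C)C2)c1`: 0.2 10^-6 cm/s

In an ADME assay on Caco-2 cells (Homo sapiens) for permeability, in the apical to basolateral direction (a higher number here means that the compound crosses the layer faster, a lower number that the compound crosses the layer more slowly), compound 2 gives 0.5 10^-6 cm/s. That places it level with compound 1, and together they stand highest of the three numbers; compound 3 sits a step below, and that gap is beyond the scatter. For the measured compounds named here, the step of no change at the digits printed from compound 1 to compound 2 (within the scatter) is the only one-place change measured, and it adds a methyl on a saturated chain carbon two bonds from a carbonyl carbon.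

Compound 4 `Cn1cncc1CN1CC(N(CC2CCN(C(=O)Nc3ccc(Br)cc3)CC2)S(=O)(=O)c2ccccn2)Cc2cc(C#N)ccc21` differs from compound 2 by (4-bromophenyl)amino in place of propyl on a carbonyl carbon. Going by the values given here, no measured step exchanges a propyl for a (4-bromophenyl)amino group, and none introduces a hydrogen-bond donor; the single measured step, which leaves the number unchanged, is much smaller than this one. Among the compounds with values here, with no step of comparable size to lean on, the expectation rests on the value of compound 2, and the estimated step of a 1.3-fold lower number from compound 2 to compound 4 (0.10 log units; within the scatter) is expected to stay within the scatter or run slightly downward.

The estimate for compound 4 in this assay is therefore 0.4 10^-6 cm/s, expected to fall between 0.15 10^-6 cm/s and 1 10^-6 cm/s.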

Compound 4, apparent permeability: 0.6 10^-6 cm/s
Estimate against measurement, compound 4: 1.5-fold (0.18 log units) below, and the stated range covers the measured number.
By their numbers in this assay, from the lowest: compound 3; then compounds 1, 2 and 4 (each within the scatter of the next).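

At the carbonyl carbon whose other neighbour is an amide-type nitrogen in a ring, this assay gives a 1.2-fold higher number from compound 2 to compound 4 (0.08 log units; within the scatter) for (4-bromophenyl)amino in place of propyl and a 1.2-fold higher number from compound 1 to compound 4 (0.08 log units; within the scatter) for (4-bromophenyl)amino in place of ethyl. The earlier step at this end of the molecule was a single added methyl, whereas this change brings in a six-membered aromatic ring of carbon only, a bromine and a hydrogen-bond donor, and both steps still lie within the scatter. Nothing available here explains this result.

On these data alone, it remains open whether a plain phenylamino group, or chlorine in place of the bromine, would read the same at this carbonyl carbon. A dimethylamino group or a chain ending in a carboxylic acid at this place also remains to be read.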